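This account rests on a few compounds, and the source may have more. Where it says the series, first, only, none or still open, it means among the compounds named here.

Measured compounds in an ADME assay on a cell-free system (plasma, Homo sapiens), read by HPLC, with a stated time of 120 min, at 37 degrees C; on this read-out lower numbers stand for a less stable compound and higher numbers for a more stable compound:
- compound 1 `C[C@@H]1CN(C(=O)c2nc(Nc3cc(C4CC4)[nH]n3)c3cc(Cl)ccc3n2)CCN1C(=O)OC(C)(C)C`: 73.7%
- compound 2 `CCCCCOC(=O)N1CCN(C(=O)c2nc(Nc3cc(C4CC4)[nH]n3)c3cc(Cl)ccc3n2)C[C@H]1C`: 74.4%
- compound 3 `CC(C)OC(=O)N1CCN(C(=O)c2nc(Nc3cc(C4CC4)[nH]n3)c3cc(Cl)ccc3n2)C[C@H]1C`: 78.5%

Compound 3 holds the highest of the three numbers in this assay, but its nearest neighbour compound 2 and its furthest neighbour compound 1 both sit within the scatter of it, so no order among the three can be read.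

Compound 4 `C[C@@H]1CN(C(=O)c2nc(Nc3cc(C4CC4)[nH]n3)c3cc(Cl)ccc3n2)CCN1C(=O)OCOC(=O)C(C)(C)C` differs from compound 3 in one place: (((tert-butyl)carbonyl)oxy)methyl in place of isopropyl on an oxygen next to a carbonyl group. The measured steps that bear on this change all vary the group on the oxygen next to the carbonyl group of the shared core: a number 0.7 percentage points higher from compound 1 to compound 2 (within the scatter), a number 4.1 percentage points higher from compound 2 to compound 3 (within the scatter) and a number 4.8 percentage points higher from compound 1 to compound 3 (within the scatter). None of them moves this assay beyond its scatter. The change to compound 4 is larger than any of these, since the entering group brings eight heavy atoms, two oxygens and two hydrogen-bond acceptors where the leaving isopropyl brought three carbons, so the measured steps cover it only loosely. Still, on what is known, no step beyond the scatter is expected; the estimate for compound 4 is 72% (range 50% to 90%), meaning an expected step of a number 6.5 percentage points lower from compound 3 to compound 4 (within the scatter).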

Compound 4, percent of the compound remaining: 0%
Beside the measured number, compound 4's estimate is 72 percentage points above it; the whole stated range lies above it.
By their numbers in this assay, from the lowest: compound 4; then compounds 1, 2 and 3 (each within the scatter of the next).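

In this assay the group on the oxygen next to a carbonyl group had seemed of little consequence, with tert-butyl, pentyl and isopropyl all within the scatter of one another, but (((tert-butyl)carbonyl)oxy)methyl gives a number 78.5 percentage points lower from compound 3 to compound 4 (beyond the scatter) and a number 74.4 percentage points lower from compound 2 to compound 4 (beyond the scatter) and a number 73.7 percentage points lower from compound 1 to compound 4 (beyond the scatter). This position therefore tolerates the three plain alkyl groups shown, yet the read-out is not indifferent to every group placed there. Nothing available bears on why the change has so large an effect.

Going by these compounds, it remains open whether the whole entering group is needed for this result, or whether a smaller acetoxymethyl or methoxymethyl group would give the same. Also open, on these data alone, is what compound 4 becomes in this assay and whether the shared core survives intact.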